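From ethyl to benzyl on a shared core

The source may report more compounds than this note shows. Statements on the series, on what has been measured and on what is new or still open speak of the compounds shown alone.

Measured so far in a functional assay on MCF7 cells (Homo sapiens) for cytotoxicity, read by MTT assay, with a stated time of 48 h (a lower number here means a stronger inhibitor of growth, a higher number a weaker inhibitor of growth), and still the only data available:

compound 1 `Fc1ccccc1-c1nc2cc(Cl)c(Cl)cc2[nH]1` gives 47500 nM
compound 2 `CCn1c(C(F)(F)F)nc2cc(Cl)c(Cl)cc21` gives 72900 nM

Compound 2 stands at 72900 nM in this assay and lies within the usual scatter of compound 1, so the two cannot be told apart on these numbers. Going by the values given here, the two compounds differ in more than one place, and no measured step therefore guides the next change.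

That change leads to compound 3 `FC(F)(F)c1nc2cc(Cl)c(Cl)cc2n1Cc1ccccc1` (phenyl in place of methyl on a saturated chain carbon bound to an aromatic nitrogen), turning ethyl into benzyl. Among the compounds with values here, no measured pair shows what this change does in this assay, so the expectation is cautious: a modest move towards a lower number, little beyond the scatter and possibly not beyond it at all. Within the data shown here, the only other reference is compound 1 at 47500 nM, and the expectation stays near that range. In this assay the expected change is a 2.4-fold lower number from compound 2 to compound 3 (0.39 log units; beyond the scatter) as an estimate. The estimated value for compound 3 is 30000 nM with 9000 nM to 90000 nM as its expected range.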

Compound 3, concentration for 50% growth inhibition: 8700 nM
The estimate for compound 3 lay 3.4-fold (0.54 log units) above the measured number, and the stated range ends above it.
By their numbers in this assay, from the lowest: compound 3; then compounds 1 and 2 (each within the scatter of the next).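

In this assay, turning ethyl into benzyl gives an 8.4-fold lower number from compound 2 to compound 3 (0.92 log units; beyond the scatter), which makes this place, a saturated chain carbon bound to an aromatic nitrogen, the first one shown to respond to a single change. The earlier compounds shown here could not show this: they differ in more than one place, offered no step to read, and could not be told apart on their numbers. Here the core and the trifluoromethyl group stay the same, so the whole step belongs to phenyl in place of methyl, although no measurement given here explains the size of that step.

The compounds shown leave open whether the aromatic ring itself matters or whether any larger group at this place would do the same, and a cyclohexylmethyl group or a longer chain such as phenylethyl would separate those readings. They also leave open whether the step from ethyl to benzyl would hold with an amine in place of the trifluoromethyl group on the shared core.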